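Shifting the pyridine nitrogen in compound 2

The source may hold more compounds than are shown below. What is called first, only, known or untested is meant among the compounds shown, and "the series" means these compounds.

The series shares a five-membered ring with two nitrogens, one bearing a chain to a substituted phenoxy group, the other a pyridinyl. Compound 1 `O=C1N(CCCCCCOc2ccc(Br)cc2)CCN1c1ccncc1` was run in a functional assay on cells (Homo sapiens) for cytotoxicity; on this read-out higher numbers stand for lower toxicity in this test and lower numbers for higher toxicity in this test; its reading is a limit, and in this assay compound 1 gives > 25000 nM. For compound 2 `O=C1N(CCCCCCCOc2ccc(Cl)cc2)CCN1c1ccncc1` the result is also a limit, and in this assay compound 2 gives > 25000 nM. Compound 3 `Cc1ccc(OCCCCCCN2CCN(c3ccncc3)C2=O)cc1` likewise returns a limit, and in this assay compound 3 gives > 25000 nM. Compound 2 thus stands where every value stands, since (the limit of > 25000 nM in this assay, at which 3 of the 3 values shown sit). The steps a step that the two limits leave unreadable from compound 1 to compound 2, a step that the two limits leave unreadable from compound 1 to compound 3 and a step that the two limits leave unreadable from compound 2 to compound 3 accordingly give no readable size.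

Compound 4 `O=C1N(CCCCCCCOc2ccc(Cl)cc2)CCN1c1cccnc1` differs from compound 2 by pyridin-3-yl in place of pyridin-4-yl on an amide-type nitrogen in a ring. Among the compounds with values here, no measured step touches the pyridinyl, so none bears directly on it; the chain and phenoxy changes all left the reading at the limit. Compound 4 is expected to stay at that limit, estimated at 25000 nM with a range from 12000 nM to 60000 nM. The estimate for compound 4 thus implies a step of a number no higher from compound 2 to compound 4 (the limit leaves the size open), none beyond the scatter.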

Compound 4, half-maximal cytotoxic concentration: > 25000 nM
Compound 4 ended at the assay's limit; the forecaster's own chance of this, stated with the estimate: 80%; the middle value sits exactly at the limit.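

No step can be read from compound 2 to compound 4, since pyridin-3-yl in place of pyridin-4-yl leaves both readings as limits, where the whole set sits: the limit of > 25000 nM in this assay, at which 4 of the 4 values shown sit.

The compounds shown leave open whether any change to the chain, phenoxy group or pyridinyl shifts the reading in this assay at all.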